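The source may hold more compounds than are shown below. What is called first, only, known or untested is meant among the compounds shown, and "the series" means these compounds.

Measured so far:
compound 1 `CC(=O)c1ccc(-c2cn3ccnc3c(-c3ccc4ncn(C5CCCCC5)c4c3)n2)cc1`, 7.65%
compound 2 `COc1ccccc1-c1cn2ccnc2c(-c2ccc3ncn(C4CCCCC4)c3c2)n1`, 15.9%

Both numbers come from a functional assay on MDA-MB-231 cells (Homo sapiens) for inhibition, read by sulforhodamine B assay, with a stated time of 48 h, tested at 10 uM; a higher number here means more inhibition at the concentration tested (going by the name of the read-out), a lower number less inhibition. Compound 2 stands level with compound 1 in this assay: the step of a number 8.3 percentage points higher from compound 1 to compound 2 (within the scatter) is within the scatter, so neither number can be called higher or lower than the other on these two numbers. Compound 3 `c1csc(-c2cn3ccnc3c(-c3ccc4ncn(C5CCCCC5)c4c3)n2)c1` has not been measured. It differs from compound 2 in one place: thiophen-2-yl in place of 2-methoxyphenyl on an aromatic carbon. For the measured compounds named here, the only measured step that bears on this position is a number 8.3 percentage points higher from compound 1 to compound 2 (within the scatter), which swapped one six-membered aromatic group for another on the same aromatic carbon without moving the read-out beyond the scatter. Nothing measured covers a five-membered ring there, so the step of a number 3.9 percentage points lower from compound 2 to compound 3 (within the scatter) is expected to be none beyond the scatter. The estimate for compound 3 in this assay is therefore 12%, in a range from 0% to 30%.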

Compound 3, a percentage reported as inhibition, at one concentration (the size of the read-out at that concentration, not a potency): 10.8%
For compound 3 the middle estimate is 1.2 percentage points above the measured one; measured number inside the range.
By their numbers in this assay, from the lowest: compounds 1, 3 and 2 (each within the scatter of the next).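

In this assay the change to a five-membered aromatic ring with a sulfur atom gives a number 5.1 percentage points lower from compound 2 to compound 3 (within the scatter) and, set against the acetyl-bearing group, a number 3.2 percentage points higher from compound 1 to compound 3 (within the scatter) in the same way. The position next to the ring nitrogen has thus now carried a five-membered ring as well as two six-membered ones, and thiophen-2-yl, which has fewer heavy atoms than 2-methoxyphenyl, leaves the read-out level with both. The three compounds cannot be separated at this one concentration, and nothing available explains this flat result.

All three groups are aromatic rings joined through carbon. What the compounds shown leave open is how an amine, a carboxylic acid or a longer alkyl chain at this position would read in this assay.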